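A Bromophenyl Analogue in a Cytotoxicity Series

A few compounds are considered here, and "the series" means these few. Any claim that something is new, unique, unknown or untested is made for them only; others in the source may bear on it.

Of the compounds shown here, three sharing one core have been measured in a functional assay on HSC-2 cells (Homo sapiens) for cytotoxicity, with a stated time of 48 h; on this read-out higher numbers stand for lower toxicity in this test and lower numbers for higher toxicity in this test. Compound 1 `Cc1c(C(=O)/C=C/c2cccc([N+](=O)[O-])c2)[n+]([O-])c2ccccc2[n+]1[O-]` gives 34000 nM in this assay. Compound 2 `COc1ccc(/C=C/C(=O)c2c(C)[n+]([O-])c3ccccc3[n+]2[O-])cc1OC` gives 25000 nM. Compound 3 `Cc1c(C(=O)/C=C/c2ccc(Cl)c(Cl)c2)[n+]([O-])c2ccccc2[n+]1[O-]` gives 17000 nM. On these numbers compound 3 sits alongside compound 1 and compound 2: the gap to compound 2 and the gap to compound 1 both fall within the usual scatter of repeated measurements, so the three compounds cannot be separated with confidence in this assay.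

Compound 4 `Cc1c(C(=O)/C=C/c2ccc(Br)cc2)[n+]([O-])c2ccccc2[n+]1[O-]` has not yet been measured. It differs from compound 3 in one place: 4-bromophenyl in place of 3,4-dichlorophenyl on a double-bonded chain carbon bound to a double-bonded chain carbon. Among the compounds with values here, no step between two measured compounds mirrors this exchange, so there is no direct precedent for its effect. The three measured compounds, carrying quite different substituted phenyl groups, all land within the scatter of one another, which gives no sign that the phenyl substituent moves the number much here.

Compound 4 is therefore expected to give about 20000 nM, with a plausible range from 8000 nM to 50000 nM. This estimate corresponds to an expected step of a 1.2-fold higher number from compound 3 to compound 4 (0.07 log units; within the scatter), that is, no change beyond the scatter.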

Compound 4, half-maximal cytotoxic concentration: 19000 nM
Beside the measured number, compound 4's estimate is 1.1-fold (0.02 log units) above it; the range from low to high includes it.
By their numbers in this assay, from the lowest: compounds 3, 4, 2 and 1 (each within the scatter of the next).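

In this assay, within the data shown here, placing 4-bromophenyl in place of 3,4-dichlorophenyl on a double-bonded chain carbon bound to a double-bonded chain carbon gives a 1.1-fold higher number from compound 3 to compound 4 (0.05 log units; within the scatter), the first direct comparison in this set between two compounds that differ in only one place. At this position, then, exchanging a phenyl ring with two chlorine atoms for one with a single bromine atom leaves compound 4 indistinguishable from compound 3, even though the two groups differ in their halogen and in their number of heavy atoms. No supporting measurement is available to explain why these two compounds read alike.

Both groups in this step are phenyl rings bearing halogens, so it says nothing about a phenyl ring carrying an amine or a carboxylic acid at this place, or about a longer alkyl chain standing in for the ring. A single step within the scatter also cannot show whether any other exchange here, or a change elsewhere on the shared core, would move the number beyond the scatter.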